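Thiosemicarbazone series: methoxy added to the hydrazone phenyl

The compounds below may be only part of what the source reports. "The series", "measured", "known", "first", "only" and "open" are said of these compounds alone.

Measured compounds:
compound 1 `CC1=CC[C@H](C(C)(C)NC(=S)NN)CC1`: 46700 nM
compound 2 `CC1=CC[C@H](C(C)(C)NC(=S)N/N=C(\C)c2ccccc2)CC1`: > 100000 nM

In a functional assay on MCF7 cells (Homo sapiens) for inhibition, read by sulforhodamine B assay, with a stated time of 48 h (a higher number here means a weaker inhibitor of growth, a lower number a stronger inhibitor of growth), compound 1 gives 46700 nM. For compound 2 the result in this assay is a limit of the assay, > 100000 nM, not a number. Compound 2 therefore sits at the limit of > 100000 nM in this assay, at which 1 of the 2 values shown sits, and only that bound is known for it.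

Compound 3 `COc1ccc(/C(C)=N/NC(=S)NC(C)(C)[C@H]2CC=C(C)CC2)cc1` is not yet measured. It differs from compound 2 by methoxy in place of hydrogen on an aromatic carbon; cut one bond further out, phenyl becomes 4-methoxyphenyl. Among the compounds with values here, no measured pair here shares this change, so nothing shows how large such a step is in this assay.

The step from compound 2 to compound 3 is expected to be small, a number no higher from compound 2 to compound 3 (the limit leaves the size open), with no direction beyond the scatter. Compound 3 is estimated at 100000 nM in this assay, within 35000 nM to 300000 nM, and a limit rather than a number is the more likely outcome.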

Compound 3, concentration for total growth inhibition: > 100000 nM
Compound 3 ended at the assay's limit; the forecaster's own chance of this, stated with the estimate: 65%; the middle value sits exactly at the limit.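

Within the data shown here, compound 3 gives > 100000 nM, a limit of the assay, and compound 2 also stands at a limit, so no step between the two can be read. The compounds shown leave open the size and direction of the change from phenyl to 4-methoxyphenyl in this assay.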